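The compounds below may be only part of what the source reports. "The series", "measured", "known", "first", "only" and "open" are said of these compounds alone.

In an ADME assay on HeLa cells (Homo sapiens) for cytotoxicity, read by MTT assay (a lower number here means a stronger inhibitor, a higher number a weaker inhibitor), compound 3 `COc1ccc(C[C@H]2COC(=O)[C@@H]2Cc2ccc(OCC(=O)N3CCCC3)c(OC)c2)cc1OC` gives >= 600000 nM, and this is a limit of the assay, not a number. Compound 4 `COc1ccc(C[C@H]2COC(=O)[C@@H]2Cc2ccc(OCc3cn(-c4ccc(Cl)cc4)nn3)c(OC)c2)cc1OC` differs from it by 1-(4-chlorophenyl)-1H-1,2,3-triazol-4-yl in place of (pyrrolidin-1-yl)carbonyl on a saturated chain carbon bound to an oxygen on an aromatic ring.

The nearest measured neighbour is compound 1 `COc1ccc(C[C@H]2COC(=O)[C@@H]2Cc2ccc(OCc3cn(-c4ccc(Br)cc4)nn3)c(OC)c2)cc1OC`, which gives 128000 nM and carries 4-bromophenyl where compound 4 carries 4-chlorophenyl. The step of an at least 4.6-fold higher number from compound 1 to compound 3 (0.67 log units; beyond the scatter) runs opposite to the change now in question and lies beyond the scatter. Compound 2 `COc1ccc(C[C@H]2COC(=O)[C@@H]2Cc2ccc(OCc3cn(Cc4ccc(F)cc4)nn3)c(OC)c2)cc1OC` gives 198000 nM. For the measured compounds named here, the step of a 1.5-fold higher number from compound 1 to compound 2 (0.19 log units; within the scatter), with 4-fluorobenzyl in place of 4-bromophenyl on an aromatic nitrogen, stays within the scatter, so the one measured change at that nitrogen left the number in place.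

On this basis a move to a lower number in this assay is expected, at least comparable in size to the reverse of the step from compound 1. The expected step is an at least 4.2-fold lower number from compound 3 to compound 4 (0.63 log units; beyond the scatter). The estimate for compound 4 is 140000 nM, with an expected range from 70000 nM to 300000 nM.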

Compound 4, half-maximal inhibitory concentration: 279000 nM
For compound 4 the middle estimate is 2.0-fold (0.30 log units) below the measured one; the range from low to high includes it.
By their numbers in this assay, from the lowest: compounds 1, 2 and 4 (each within the scatter of the next, the first and the last beyond it). At a limit, above all of these: compound 3.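

In this assay, compound 4 gives a second case of an aryl triazole on the saturated chain carbon bound to an oxygen on an aromatic ring, and 1-(4-chlorophenyl)-1H-1,2,3-triazol-4-yl in place of (pyrrolidin-1-yl)carbonyl gives an at least 2.1-fold lower number from compound 3 to compound 4 (0.33 log units; beyond the scatter), the same direction as the bromo compound showed. For the compounds shown here, compound 3 stands at a limit, so this step gives only a bound and not a size: the limit of >= 600000 nM in this assay, at which 1 of the 4 values shown sits. What is new is that the single exchange of chloro in place of bromo on an aromatic carbon gives a 2.2-fold higher number from compound 1 to compound 4 (0.34 log units; beyond the scatter), whereas 4-chlorophenyl in place of 4-fluorobenzyl on an aromatic nitrogen gives only a 1.4-fold higher number from compound 2 to compound 4 (0.15 log units; within the scatter).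

As far as these compounds go, the step between the two halogens rests on one pair, so it remains open whether an unsubstituted phenyl, a methoxy or a nitrile in place of chloro would continue it. From the compounds shown here alone, it also remains open whether a carboxylic acid or an amine in place of the triazole on the saturated chain carbon would stay with the triazoles or with compound 3 in this assay.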